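Two cores carrying the same acyl exchange

This account rests on a few compounds, and the source may have more. Where it says the series, first, only, none or still open, it means among the compounds named here.

In a functional assay on NCI-H23 cells (Homo sapiens) for cytotoxicity, read by sulforhodamine B assay, with a stated time of 72 h (on this read-out higher numbers stand for weaker inhibition of growth and lower numbers for stronger inhibition of growth), compound 1 `CC(=O)N1c2ccccc2CCC1C(=O)Nc1ccccc1O` gives 65700 nM. Compound 2 `O=C(Nc1ccccc1O)C1CCc2ccccc2N1C(=O)c1ccccc1Cl` differs from it by 2-chlorophenyl in place of methyl on a carbonyl carbon and gives 46900 nM in this assay, a change of a 1.4-fold lower number from compound 1 to compound 2 (0.15 log units; within the scatter). Compound 3 `CC(=O)N1c2ccccc2CCC1C(=O)Nc1ccccc1C(F)(F)F` differs from compound 1 by trifluoromethyl in place of hydroxy on an aromatic carbon. In this assay compound 3 gives only a limit, > 80000 nM, not a number. The resulting comparison reads an at least 1.2-fold higher number from compound 1 to compound 3 (0.08 log units; that floor lies within the scatter).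

Compound 4 `O=C(Nc1ccccc1C(F)(F)F)C1CCc2ccccc2N1C(=O)c1ccccc1Cl` is not yet measured in this assay. It differs from compound 3 by 2-chlorophenyl in place of methyl on a carbonyl carbon, the same kind of change that separates compound 2 from compound 1; the place lines are identical word for word, so only the cores differ, as set out for compound 3 against compound 1.

Because compound 3 sits at the limit of > 80000 nM in this assay, at which 1 of the 3 values shown sits, and because the same exchange gave only a 1.4-fold lower number from compound 1 to compound 2 (0.15 log units; within the scatter), compound 4 is expected to move by roughly a number no higher from compound 3 to compound 4 (the limit leaves the size open), most likely again ending as a limit. Compound 4 is therefore estimated at 80000 nM, within a range from 40000 nM to 200000 nM.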

Compound 4, concentration for 50% growth inhibition: 2150 nM
Estimate against measurement, compound 4: 37-fold (1.57 log units) above; measured number outside the range, below it.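

In this assay, the exchange of methyl for 2-chlorophenyl on a carbonyl carbon does not carry over unchanged from one core to the other, giving an at least 37-fold lower number from compound 3 to compound 4 (1.57 log units; beyond the scatter), a step well apart from the earlier one: the same change on two cores in this assay, a 1.4-fold lower number (0.15 log units; within the scatter) from compound 1 to compound 2 and an at least 37-fold lower number (1.57 log units; beyond the scatter) from compound 3 to compound 4, at least 26-fold (1.42 log units) apart, beyond the scatter of two such steps

Read the other way, trifluoromethyl in place of hydroxy on an aromatic carbon gives a 22-fold lower number from compound 2 to compound 4 (1.34 log units; beyond the scatter), so the large drop in the number appears only where 2-chlorophenyl and trifluoromethyl occur together, and this step too stands apart from its earlier counterpart: the same change on two cores in this assay, an at least 1.2-fold higher number (0.08 log units; that floor lies within the scatter) from compound 1 to compound 3 and a 22-fold lower number (1.34 log units; beyond the scatter) from compound 2 to compound 4, at least 26-fold (1.42 log units) apart, beyond the scatter of two such steps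

As far as these compounds go, compound 3 gives only a limit, > 80000 nM, so the full size of its step stays open, and this single set of four compounds gives no reason for the gap and no sign of whether it holds elsewhere.

The compounds shown leave open whether the large step needs 2-chlorophenyl itself or would also appear with a plain phenyl or a cyclohexyl on the carbonyl carbon. They also leave open whether a nitrile or a methoxy group on the aromatic carbon in place of trifluoromethyl would pair with 2-chlorophenyl in the same way.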